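Swapping a Nitrile for Two Chlorines on the Outer Ring

The source may report more compounds than this note shows. Statements on the series, on what has been measured and on what is new or still open speak of the compounds shown alone.

Compound 3 `Cc1cc(-c2cccc(C#N)c2)cc(C)c1Nc1ccnc(Nc2ccc(C#N)cc2)n1` is the least tolerated of the three in an ADME assay on MT4 cells (Homo sapiens) for cytotoxicity, read by MTT assay, with a stated time of 4 days (a lower number here means that less compound is tolerated, a higher number that more compound is tolerated), giving 920 nM. Compound 1 `Cc1cc(-c2ccc(F)cc2)cc(C)c1Nc1ccnc(Nc2ccc(C#N)cc2)n1` gives 4170 nM in this assay, and compound 2 `Cc1cc(-c2cccc(C(F)(F)F)c2)cc(C)c1Nc1ccnc(Nc2ccc(C#N)cc2)n1` gives 4030 nM. Among the measured steps, a 1.0-fold lower number from compound 1 to compound 2 (0.01 log units; within the scatter), whereas a 4.5-fold lower number from compound 1 to compound 3 (0.66 log units; beyond the scatter) and a 4.4-fold lower number from compound 2 to compound 3 (0.64 log units; beyond the scatter). Compound 4 `Cc1cc(-c2cc(Cl)cc(Cl)c2)cc(C)c1Nc1ccnc(Nc2ccc(C#N)cc2)n1` differs from compound 3 in that (3,5-dichlorophenyl in place of 3-cyanophenyl on an aromatic carbon). The comparison of compound 2 with compound 3 bears most on this change, because a 4.4-fold lower number from compound 2 to compound 3 (0.64 log units; beyond the scatter) marked the arrival of the nitrile that now departs in favour of a group with no hydrogen-bond acceptor. A modest move back toward compound 1 and compound 2 is therefore expected, a 3.6-fold higher number from compound 3 to compound 4 (0.55 log units; beyond the scatter). Compound 4 is estimated at 3300 nM, with a range from 1200 nM to 8500 nM.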

Compound 4, half-maximal cytotoxic concentration: 4290 nM
For compound 4 the middle estimate is 1.3-fold (0.11 log units) below the measured one, within the range that was stated.
By their numbers in this assay, from the lowest: compound 3; then compounds 2, 1 and 4 (each within the scatter of the next).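

In this assay, the change to 3,5-dichlorophenyl gives a 4.7-fold higher number from compound 3 to compound 4 (0.67 log units; beyond the scatter), and this outer ring lands level with the other two nitrile-free rings, with a 1.1-fold higher number from compound 2 to compound 4 (0.03 log units; within the scatter) and a 1.0-fold higher number from compound 1 to compound 4 (0.01 log units; within the scatter). Across these four compounds, then, only the one carrying the nitrile stands apart, and no compound goes against this. Nothing available explains why this is so. Going by these compounds, whether an amine or a methoxy group at this place would group with compound 3 or with the other three stays open.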